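Chain lengthening on the amide nitrogen of compound 1

A few compounds are considered here, and "the series" means these few. Any claim that something is new, unique, unknown or untested is made for them only; others in the source may bear on it.

Compound 1 `CCCCCCCCNC(=O)[C@@H](NC(=O)c1ccccc1)[C@@H](C)O` is the parent of this small set. In a functional assay on SW-620 cells (Homo sapiens) for cytotoxicity, read by MTT assay, with a stated time of 48 h (a lower number here means a stronger inhibitor, a higher number a weaker inhibitor), compound 1 gives 200000 nM. Compound 3 `C/C=C/C=C/C(=O)N[C@H](C(=O)NCCCCCCCC)[C@@H](C)O` gives 200000 nM in this assay, and no change at the digits printed from compound 1 to compound 3 (within the scatter). Compound 2 `CCCCCCCCNC(=O)[C@@H](NC(=O)/C=C/c1ccccc1)[C@@H](C)O` gives 61400 nM in this assay; a 3.3-fold lower number from compound 1 to compound 2 (0.51 log units; beyond the scatter), and a 3.3-fold higher number from compound 2 to compound 3 (0.51 log units; beyond the scatter). Compound 1 therefore stands level with compound 3 at the digits shown, and the two together hold the highest number of the three, with compound 2 the only one set apart.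

Compound 4 `CCCCCCCCCCCCCCCCCCNC(=O)[C@@H](NC(=O)c1ccccc1)[C@@H](C)O` differs from compound 1 by decyl in place of hydrogen on a saturated chain carbon, eight bonds along the chain from an amide-type nitrogen. Within the data shown here, all three measured steps change the group on the acyl carbonyl carbon; none alters the chain on the other amide nitrogen, so no measured step bears directly on this change. The measured numbers span only a modest interval altogether, and nothing in them points in a direction for a longer chain. No step beyond the scatter is expected, so no change at the digits printed from compound 1 to compound 4 (within the scatter) is the estimated outcome. Compound 4 is expected to give 200000 nM in this assay, within a range of 60000 nM to 400000 nM.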

Compound 4, half-maximal inhibitory concentration: 200000 nM
Compound 4: the middle estimate sits on the measured number at the digits printed; low and high end bracket the measured number.
By their numbers in this assay, from the lowest: compound 2; then compounds 1, 3 and 4 (each within the scatter of the next).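

Set against the octyl-type chain of compound 1, the longer chain at this position gives no change at the digits printed from compound 1 to compound 4 (within the scatter) in this assay and is the first reading on this amide nitrogen side of the series. Decyl in place of hydrogen at eight bonds along the chain from an amide-type nitrogen therefore leaves the number where it stood in this pair. Among these compounds, the only change beyond the scatter for compound 1 remains at the carbonyl carbon, where the step reads a 3.3-fold lower number from compound 1 to compound 2 (0.51 log units; beyond the scatter) and the chain is untouched. No measured evidence bears on why the chain extension leaves the number in place.

Open, on these data alone, is whether a shorter chain, or a chain ending in an amine or a carboxylic acid, would move the number at this position. Among the compounds shown here, also open is whether decyl in place of hydrogen would leave compound 2 equally unmoved, since it carries the one acyl group that stands apart.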